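The compounds below may be only part of what the source reports. "The series", "measured", "known", "first", "only" and "open" are said of these compounds alone.

Working notes on the series. In an ADME assay on J774.A1 cells (Mus musculus) for cytotoxicity, read by MTT assay, with a stated time of 48 h (on this read-out higher numbers stand for lower toxicity in this test and lower numbers for higher toxicity in this test), compound 1 (`COC(=O)c1c([N+](=O)[O-])noc1-c1cc(-c2ccccc2Cl)n(-c2ccccc2)n1`) gives 79900 nM, and compound 2 (`COc1ccc(CNC(=O)c2c([N+](=O)[O-])noc2-c2ccc([N+](=O)[O-])cc2)cc1`) gives 69600 nM. Going by the values given here, these two values lie within the usual scatter of each other, so compound 2 stands level with compound 1 on the only numbers available.

Compound 3 (`CC(C)CCNC(=O)c1c([N+](=O)[O-])noc1-c1ccc([N+](=O)[O-])cc1`) is still unmeasured. It departs from compound 2 in one place: isobutyl in place of 4-methoxyphenyl on a saturated chain carbon bound to an amide-type nitrogen. In words, isobutyl stands in place of 4-methoxyphenyl on a saturated chain carbon bound to an amide-type nitrogen. The same difference, cut one bond further out, reads 4-methoxybenzyl to isopentyl.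

Among the compounds with values here, no measured pair differing in one place is available, so the size of this change in this assay has no direct guide. Within the data shown here, the only support is that compound 1 at 79900 nM and compound 2 at 69600 nM sit within the scatter, which offers no sign of a large move in either direction. The expected outcome is therefore no shift beyond the scatter.

The estimated step, a 1.1-fold higher number from compound 2 to compound 3 (0.03 log units; within the scatter), carries no firm direction. For compound 3 the estimated value is 75000 nM, with an expected range of 35000 nM to 150000 nM.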

Compound 3, half-maximal cytotoxic concentration: 67000 nM
Beside the measured number, compound 3's estimate is 1.1-fold (0.05 log units) above it; the measured number falls inside the stated range.
By their numbers in this assay, from the lowest: compounds 3, 2 and 1 (each within the scatter of the next).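

In this assay, going by these compounds alone, isobutyl in place of 4-methoxyphenyl on a saturated chain carbon bound to an amide-type nitrogen gives a 1.0-fold lower number from compound 2 to compound 3 (0.02 log units; within the scatter), the first direct reading of a change at this position, and it stays within the scatter. In this one pair, the six-membered aromatic ring and the single hydrogen-bond acceptor of the 4-methoxyphenyl group can leave, and the heavy atoms of the group can drop from 8 to the 4 of isobutyl, without a step beyond the scatter, so neither group stands apart from the other on this read-out. Nothing measured here bears on why the two groups read alike.

Still open, as far as these compounds go, is whether this position stays as flat for groups of another kind, such as a carboxylic acid, a terminal tertiary amine or a longer chain like n-octyl in place of isopentyl. Within the data shown here, this single pair also leaves open whether the same exchange would read alike on a core other than the one shared by compound 2 and compound 3.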